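This account rests on a few compounds, and the source may have more. Where it says the series, first, only, none or still open, it means among the compounds named here.

Measured in a functional assay on KB cells (Homo sapiens) for inhibition, read by sulforhodamine B assay, with a stated time of 72 h; on this read-out higher numbers stand for weaker inhibition of growth and lower numbers for stronger inhibition of growth:
Compound 1 `CCOC(=O)/C=C/c1ccncc1-c1ccc2c(cnn2C)c1`: > 10000 nM
Compound 2 `CNC(=O)/C=C/c1ccncc1-c1ccc2cc[nH]c2c1`: > 10000 nM

Compound 2 gives > 10000 nM in this assay, and this entry is a limit of the assay and not a number. Compound 1 is reported in the same way. The position of compound 2 is therefore shared with compound 1: the limit of > 10000 nM in this assay, at which 2 of the 2 values shown sit.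

The next compound to be tested is compound 3 `O=C(O)/C=C/c1ccncc1-c1ccc2cc[nH]c2c1`, which keeps the core of compound 2 and changes one group. The change is hydroxy in place of methylamino on a carbonyl carbon. In words, hydroxy takes the place of methylamino on a carbonyl carbon, so that methylcarbamoyl becomes carboxy, or 2-(methylcarbamoyl)ethenyl becomes 2-carboxyethenyl.

Among the measured compounds shown here, no measured pair here shows what this exchange does in this assay, so the expectation rests only on the shared limit, (the limit of > 10000 nM in this assay, at which 2 of the 2 values shown sit). No clear gain in growth inhibition is expected, and the most likely report is again a limit. The expected step that the limit leaves unreadable from compound 2 to compound 3 is no larger than the scatter, or leans slightly towards weaker inhibition. For compound 3 the estimate is 15000 nM, with an expected range of 8000 nM to 30000 nM.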

Compound 3, concentration for 50% growth inhibition: > 10000 nM
Compound 3 ended at the assay's limit (the forecaster's own chance of this, stated with the estimate: 90%); the middle value does not contradict the limit.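

Among the compounds shown here, compound 2 and compound 3 both stand at a limit of this assay and not at a number, so no step between them can be read. All the compounds shown share one position: the limit of > 10000 nM in this assay, at which 3 of the 3 values shown sit. They leave open whether hydroxy or methylamino on the carbonyl carbon gives stronger inhibition of growth, and which change would bring a measurable value.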